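This account rests on a few compounds, and the source may have more. Where it says the series, first, only, none or still open, it means among the compounds named here.

In a functional assay on RS4-11 cells (Homo sapiens) for inhibition, read by CCK-8 assay, with a stated time of 48 h (a lower number here means a stronger inhibitor, a higher number a weaker inhibitor), compound 3 `Cc1cc(C)cc(NC(=O)NCCNS(=O)(=O)c2ccc(-c3ccccc3OCc3cccc(O)c3)s2)c1` gives 5800 nM and compound 2 `O=[N+]([O-])c1ccc(NC(=S)NCCNS(=O)(=O)c2ccc(-c3ccccc3OCc3cccc(O)c3)s2)cc1` gives 10100 nM, two values within the scatter of each other. Compound 1 `O=C(NCCNS(=O)(=O)c1ccc(-c2ccccc2OCc2cccc(O)c2)s1)Nc1cc(Cl)cc(Cl)c1` gives > 50000 nM, which is a limit of the assay and not a number. Compound 4 `COc1ccc(NC(=O)NCCNS(=O)(=O)c2ccc(-c3ccccc3OCc3cccc(O)c3)s2)cc1` has 4-methoxyphenyl in place of the 3,5-dimethylphenyl of compound 3 on an amide-type nitrogen: 4-methoxyphenyl in place of 3,5-dimethylphenyl on an amide-type nitrogen. Among the measured compounds shown here, two measured steps bear on this change. The first is an at least 8.6-fold lower number from compound 1 to compound 3 (0.93 log units; beyond the scatter), with 3,5-dimethylphenyl replacing 3,5-dichlorophenyl, so this group can matter. The second is a 1.7-fold lower number from compound 2 to compound 3 (0.24 log units; within the scatter), which stays within the scatter. Neither tests 4-methoxyphenyl directly, so no step beyond the scatter is expected in this assay. The expected change is a 1.3-fold higher number from compound 3 to compound 4 (0.11 log units; within the scatter). Compound 4 is estimated at 7500 nM, with an expected range of 2500 nM to 25000 nM.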

Compound 4, half-maximal inhibitory concentration: 9400 nM
The estimate for compound 4 lay 1.3-fold (0.10 log units) below the measured number; measured number inside the range.
By their numbers in this assay, from the lowest: compounds 3, 4 and 2 (each within the scatter of the next). At a limit, above all of these: compound 1.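

In this assay, 4-methoxyphenyl in place of 3,5-dimethylphenyl gives a 1.6-fold higher number from compound 3 to compound 4 (0.21 log units; within the scatter), so bringing an oxygen into this group leaves the number within the scatter. Exchanging the whole group on the amine nitrogen gives a 1.1-fold lower number from compound 2 to compound 4 (0.03 log units; within the scatter), also within the scatter. Only the 3,5-dichlorophenyl group stands apart, with an at least 5.3-fold lower number from compound 1 to compound 4 (0.72 log units; beyond the scatter), a step that starts from a limit of the assay and not a number: the limit of > 50000 nM in this assay, at which 1 of the 4 values shown sits.

As far as these compounds go, whether an unsubstituted phenyl, a pyridine or an alkyl chain on this amide-type nitrogen would move the number beyond the scatter stays open. The compounds shown also do not tell why the 3,5-dichlorophenyl group differs from the others.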